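From Hydroxymethyl to Carboxy: One Change, One Open Question

The compounds below may be only part of what the source reports. "The series", "measured", "known", "first", "only" and "open" are said of these compounds alone.

In a functional assay on Rec1 cells (Homo sapiens) for inhibition, read by luminescence and CellTiter-Glo, with a stated time of 72 h (a lower number here means a stronger inhibitor, a higher number a weaker inhibitor), compound 1 `O=C(CCl)N1CCCC(n2nc(-c3ccc(Oc4ccccc4)cc3)cc2CO)C1` gives 400 nM and stands level with compound 2 `O=C(CCl)Nc1ccc(Cn2nc(-c3ccc(Oc4ccccc4)cc3)cc2CO)cc1` at 400 nM and compound 3 `CCOC(=O)c1cc(-c2ccc(Oc3ccccc3)cc2)nn1Cc1cccc(NC(=O)CCl)c1` at 400 nM even though the three structures differ visibly. Compound 4 `O=C(O)c1cc(-c2ccc(Oc3ccccc3)cc2)nn1C1CCCN(C(=O)CCl)C1` has not yet been measured. It departs from compound 1 in a single place, with carboxy in place of hydroxymethyl on an aromatic carbon and the rest of the molecule unchanged. For the measured compounds named here, none of the measured compounds carries this carboxy group, so the numbers offer no direct guide and any forecast stays uncertain. The expected change in this assay is a 3.8-fold higher number from compound 1 to compound 4 (0.57 log units; beyond the scatter) in the direction of a weaker inhibitor, beyond the usual scatter but not dramatic. For compound 4 the estimate is 1500 nM with an expected range of 400 nM to 6000 nM in this measurement.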

Compound 4, half-maximal inhibitory concentration: 2200 nM
Compound 4: middle estimate off by 1.5-fold (0.17 log units), on the low side, within the range that was stated.
By their numbers in this assay, from the lowest: compounds 1, 2 and 3 (each within the scatter of the next); then compound 4.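

Moving from hydroxymethyl to carboxy on this aromatic carbon in this assay gives a 5.5-fold higher number from compound 1 to compound 4 (0.74 log units; beyond the scatter) and so shows that this position responds to the group it carries. The loss is partial, since compound 4 still gives 2200 nM in this measurement. Nothing available explains why the number rises.

From the compounds shown here alone, whether an aminomethyl group or a primary carboxamide on this carbon would stay level with compound 1 remains open. A single step also cannot show whether the same swap would cost as much on a different core.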